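The source may report more compounds than this note shows. Statements on the series, on what has been measured and on what is new or still open speak of the compounds shown alone.

Working notes on the series, read in a functional assay on MGC-803 cells (Homo sapiens) for inhibition, read by CCK-8 assay, with a stated time of 48 h; a higher number here means a weaker inhibitor, a lower number a stronger inhibitor. Compound 1 `COc1ccc(CN(C(=O)CSC(=S)N2CCCC2)c2cc(OC)c(OC)c(OC)c2)cc1` gives > 20000 nM, which is a limit of the assay and not a number. Compound 2 `COc1ccc(CN(C(=O)CSC(=S)N2CCN(C(=O)OC(C)(C)C)CC2)c2ccc(Br)cc2)cc1` gives > 20000 nM, again a limit and not a number. Among the compounds with values here, compound 3 `COc1cc(N(Cc2ccc(C)cc2)C(=O)CSC(=S)N2CCN(C(=O)OC(C)(C)C)CC2)cc(OC)c1OC` gives 16700 nM, the only true number so far, so it has no measured neighbour to be ranked against. The remaining context for it is the limit of > 20000 nM in this assay, at which 2 of the 3 values shown sit.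

Compound 4 `COc1ccc(CN(C(=O)CSC(=S)N2CCN(C(=O)OC(C)(C)C)CC2)c2cc(OC)c(OC)c(OC)c2)cc1O` is the next to be read in this assay. It departs from compound 3 at one place: 3-hydroxy-4-methoxyphenyl in place of 4-methylphenyl on a saturated chain carbon bound to an amide-type nitrogen. Put another way, 3-hydroxy-4-methoxybenzyl replaces 4-methylbenzyl, and the entering ring carries a hydrogen-bond donor that compound 3 lacks.

Within the data shown here, no step between measured compounds is available to size this change, so the expectation is a judgement and a wide one. Compound 3 at 16700 nM leaves little room in the weaker direction, so a move towards stronger inhibition, well beyond the scatter, is expected. The expected change is a 42-fold lower number from compound 3 to compound 4 (1.62 log units; beyond the scatter). For compound 4 the estimated value is 400 nM, with an expected range of 20 nM to 10000 nM.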

Compound 4, half-maximal inhibitory concentration: 82 nM
Compound 4: middle estimate off by 4.9-fold (0.69 log units), on the high side; measured number inside the range.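

In this assay, within the data shown here, the change to 3-hydroxy-4-methoxyphenyl in place of 4-methylphenyl on a saturated chain carbon bound to an amide-type nitrogen gives a 200-fold lower number from compound 3 to compound 4 (2.31 log units; beyond the scatter), the first measured step, and it shows that this position can strongly alter the read-out with the rest of the structure held constant. The earlier compounds shown here could not show this, as no pair among them differed in one place and compound 1 and compound 2 stand only at a limit of the assay, not at a number: the limit of > 20000 nM in this assay, at which 2 of the 4 values shown sit. The step is also a combined one, since the entering ring brings a hydrogen-bond donor and hydrogen-bond acceptors together, and a single pair cannot assign the effect to any one of these features.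

The compounds shown leave open whether the hydroxyl or the methoxy group accounts for the step, or whether both are needed on the ring. They also leave open how a primary amine or a carboxylic acid on the same ring would read in this assay.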